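Swapping a Carbamate Side Chain for Phenyl

A few compounds are considered here, and "the series" means these few. Any claim that something is new, unique, unknown or untested is made for them only; others in the source may bear on it.

Values in a functional assay on SK-OV-3 cells (Homo sapiens) for antiproliferative activity, read by MTT assay, with a stated time of 72 h (a lower number here means a stronger inhibitor, a higher number a weaker inhibitor), are:
Compound 1 `O=C(CCc1cccc2c1B(O)OC2)Nc1ccc(Br)cc1` at 9200 nM
Compound 2 `CC(C)(C)OC(=O)Nc1ccc(NC(=O)CCc2cccc3c2B(O)OC3)cc1` at > 100000 nM as a limit of the assay, not a number
Compound 3 `CC(C)(C)OC(=O)NCc1ccc(NC(=O)CCc2cccc3c2B(O)OC3)cc1` at 2000 nM

Compound 3 has the lower of the two true numbers, with compound 1 nearest. Compound 4 `O=C(CCc1cccc2c1B(O)OC2)Nc1ccc(-c2ccccc2)cc1` puts phenyl in place of ((tert-butoxycarbonyl)amino)methyl on an aromatic carbon. Changes at this carbon have mattered: the data show a 4.6-fold lower number from compound 1 to compound 3 (0.66 log units; beyond the scatter) as a modest step, an at least 50-fold lower number from compound 2 to compound 3 (1.69 log units; beyond the scatter) as a large one and an at least 10-fold higher number from compound 1 to compound 2 (1.03 log units; beyond the scatter) as another large one. Compound 1 is the only measured case without a tert-butoxycarbonyl group there, so its 9200 nM is the best guide and a modest rise from compound 3 is expected. The expected step is a 3.0-fold higher number from compound 3 to compound 4 (0.48 log units; beyond the scatter) in this assay with wide uncertainty. Compound 4 is expected at 6000 nM with 1500 nM to 25000 nM as its likely range.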

Compound 4, half-maximal inhibitory concentration: 48000 nM
Estimate against measurement, compound 4: 8.0-fold (0.90 log units) below; measured number above the stated range.
By their numbers in this assay, from the lowest: compound 3; then compound 1; then compound 4. At a limit, above all of these: compound 2.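

Phenyl on this aromatic carbon gives a weaker result than either bromo or ((tert-butoxycarbonyl)amino)methyl, with a 24-fold higher number from compound 3 to compound 4 (1.38 log units; beyond the scatter) and a 5.2-fold higher number from compound 1 to compound 4 (0.72 log units; beyond the scatter). So compound 1, the one earlier case without a tert-butoxycarbonyl group, did not predict how a group lacking it would behave here. Phenyl still improves on (tert-butoxycarbonyl)amino, with an at least 2.0-fold lower number from compound 2 to compound 4 (0.31 log units; beyond the scatter), but compound 2 gives only a limit and not a number: the limit of > 100000 nM in this assay, at which 1 of the 4 values shown sits.

As far as these compounds go, it remains open how a free aminomethyl group or a carboxylic acid on this carbon would compare with compound 3. A longer chain ending in the tert-butoxycarbonyl group is equally untested by these compounds.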